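The source may report more compounds than this note shows. Statements on the series, on what has been measured and on what is new or still open speak of the compounds shown alone.

So far two compounds built on the same core have been measured. In a functional assay on MCF-A cells (Homo sapiens) for cytotoxicity (on this read-out lower numbers stand for stronger inhibition of growth and higher numbers for weaker inhibition of growth), compound 2 (`CSc1ccc(C2=C(c3ccc(O)c(O)c3)C(=O)N3CCCC3C2)cc1`) gives 80000 nM and stands highest of the two numbers, while compound 1 (`COc1ccc(C2=C(c3ccc(SC)cc3)CC3CCCN3C2=O)cc1C`) gives 400 nM on the same read-out.

Compound 3 (`COc1ccc(C2=C(c3ccc(SC)cc3)CC3CCCN3C2=O)cc1`) differs from compound 2 in one place (4-methoxyphenyl in place of 3,4-dihydroxyphenyl on a double-bonded ring carbon), with 4-methoxyphenyl in place of 3,4-dihydroxyphenyl on a double-bonded ring carbon. Going by the values given here, one measured step bears on this change: a 200-fold higher number from compound 1 to compound 2 (2.30 log units; beyond the scatter) with 3,4-dihydroxyphenyl in place of 4-methoxy-3-methylphenyl on a double-bonded ring carbon, a large change well beyond the scatter.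

Among the compounds with values here, compound 3 runs the opposite way, giving up the 3,4-dihydroxyphenyl for a group that differs from the one in compound 1 only by lacking the methyl. Within the data shown here, no measurement yet shows what that methyl does alone, so the return may not be complete. A large fall in the number is therefore expected, estimated as a 130-fold lower number from compound 2 to compound 3 (2.12 log units; beyond the scatter) in this assay and nearly as large as the step already described. For compound 3 the estimated value is 600 nM (expected range 120 nM to 3500 nM).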

Compound 3, concentration for 50% growth inhibition: 5000 nM
Compound 3: middle estimate off by 8.3-fold (0.92 log units), on the low side, outside the stated range (above it).
By their numbers in this assay, from the lowest: compound 1; then compound 3; then compound 2.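

In this assay, the earlier large step at this double-bonded ring carbon now comes apart into two pieces. Putting 4-methoxyphenyl in place of 3,4-dihydroxyphenyl gives a 16-fold lower number from compound 2 to compound 3 (1.20 log units; beyond the scatter), which goes only part of the way back to the number of compound 1. Going by these compounds alone, the rest of the distance belongs to one small group: hydrogen in place of methyl on an aromatic carbon gives a 13-fold higher number from compound 1 to compound 3 (1.10 log units; beyond the scatter), a large step for so small an edit, and one that the first pair of compounds could not separate from the exchange of the hydroxy groups. Both the loss of the 3,4-dihydroxyphenyl and the presence of that methyl therefore matter in this series, and each step alone lies beyond the scatter.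

Still open, from the compounds shown here alone, is whether an ethyl group or a chlorine atom could stand where the methyl stands, and whether 4-hydroxyphenyl, with a single hydroxy group, would fall closer to compound 2 or to compound 3. Nothing available explains why either step is as large as it is.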